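Bromine on the phenoxy ring of a spiro-fused triazine

The source may report more compounds than this note shows. Statements on the series, on what has been measured and on what is new or still open speak of the compounds shown alone.

Measured compounds:
compound 2, `CC(C)(C)c1ccc(OCCCON2C(N)=NC(N)=NC23CCSCC3)cc1`: 1 nM
compound 3, `NC1=NC2(CCSCC2)N(OCCCOc2cccc(Cl)c2)C(N)=N1`: 130 nM

Compound 1, `NC1=NC2(CCOCC2)N(OCCCOc2ccccc2)C(N)=N1`, carries an unsubstituted phenoxy group on the chain that leaves the core. In a functional assay on MDA-MB-231 cells (Homo sapiens) for antiproliferative activity, read by MTT assay, with a stated time of 72 h (on this read-out lower numbers stand for stronger inhibition and higher numbers for weaker inhibition), compound 1 is recorded as "not determined" (no result reported), so there is no number to place it against its neighbours. Compound 2 gives 1 nM in this assay, and compound 3 gives 130 nM; both share a core with a sulfur-containing spiro ring, which differs from the oxygen-containing spiro ring of compound 1.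

Compound 4, `NC1=NC2(CCOCC2)N(OCCCOc2cccc(Br)c2)C(N)=N1`, keeps the core of compound 1 and changes the phenoxy group: bromo in place of hydrogen on an aromatic carbon. The bromo group sits meta to a large group on the six-membered aromatic ring of carbon only.

For the measured compounds named here, no step between measured compounds is recorded, and compound 1 itself has no value, so no direction or size of step in this assay can be read from compound 1. The closest measured guide is compound 3, whose chloro group sits in the same place on the ring and whose value is 130 nM. Compound 4 is expected to land at 150 nM, in a range from 30 nM to 800 nM.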

Compound 4, half-maximal inhibitory concentration: 400 nM
Compound 4: the middle estimate sits 2.7-fold (0.43 log units) below what was measured; low and high end bracket the measured number.
By their numbers in this assay, from the lowest: compound 2; then compound 3; then compound 4.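

No step can be read from compound 1 to compound 4 in this assay, and compound 4 differs from compound 2 and compound 3 in more than one place. The compounds shown leave open what the bromo group alone changes on the core of compound 1. No measurement shown offers an explanation for the value of compound 4.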